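Removing a nitro group from a phthalimide-bearing amide

A few compounds are considered here, and "the series" means these few. Any claim that something is new, unique, unknown or untested is made for them only; others in the source may bear on it.

Within the data shown here, compound 3 `O=C(Nc1ccc(Cl)cc1CN1C(=O)c2ccccc2C1=O)c1ccccc1[N+](=O)[O-]` is the one compound in this set with a measured number: in an assay on CHO cells for positive allosteric modulation of metabotropic glutamate receptor 5 (Homo sapiens), read by FLIPR (a lower number here means that less compound is needed, a higher number that more compound is needed for the effect), compound 3 gives 5700 nM. The two companions sit at a limit instead. Compound 1 `O=C(Nc1cccc(F)c1CN1C(=O)c2ccccc2C1=O)c1ccccn1` reaches only the limit of > 100000 nM in this assay, which is a limit and not a number. Compound 2 `COc1ccc2c(c1OC)C(=O)N(Cc1cc(Br)ccc1NC(=O)c1ccccn1)C2=O` likewise gives > 100000 nM in this assay, again a limit. Since two of the three results stop at that limit (the limit of > 100000 nM in this assay, at which 2 of the 3 values shown sit), compound 3 stands alone as the only point from which a step can be judged.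

Compound 4 `O=C(Nc1ccc(Cl)cc1CN1C(=O)c2ccccc2C1=O)c1ccccc1` differs from compound 3 in one place: hydrogen in place of nitro on an aromatic carbon. Among the measured compounds shown here, no measured pair in this set shows what such a change does. The expectation is a step of a 2.6-fold higher number from compound 3 to compound 4 (0.42 log units; beyond the scatter) toward weaker modulation, that is, more compound needed in this assay. Compound 4 is therefore estimated at 15000 nM, with a range from 4000 nM to 60000 nM.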

Compound 4, half-maximal effective concentration: > 100000 nM
Compound 4 ended at the assay's limit (the forecaster's own chance of this, stated with the estimate: 30%); middle value at least 6.6-fold (0.82 log units) away from the limit.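

Among these compounds, the pair of compound 3 and compound 4 is the first in this set to differ in one place, and it shows that the nitro group, on an aromatic carbon and ortho to a large group, cannot simply be dropped in this assay: the change from 2-nitrophenyl to phenyl gives an at least 17-fold higher number from compound 3 to compound 4 (1.24 log units; beyond the scatter). Compound 4 gives > 100000 nM, which is a limit and not a number, so the step has a floor but no measured size. With this result, compound 3 remains the only compound with a number, and the others stop at the limit: the limit of > 100000 nM in this assay, at which 3 of the 4 values shown sit.

This single pair cannot tell why the nitro group matters. It also leaves open whether another group at the same place, such as an amine, a nitrile or a carboxylic acid, would restore a measurable value.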